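Swapping a difluorophenyl pattern on a quinoline sulfone

The source may hold more compounds than are shown below. What is called first, only, known or untested is meant among the compounds shown, and "the series" means these compounds.

Measured in an ADME assay on microsomes from liver (Homo sapiens) for metabolic stability, tested at 2.5 uM; a lower number here means slower removal, a higher number faster removal of the compound:
Compound 1 `O=S(=O)(c1cc(F)cc(F)c1)c1cnc2cc(F)ccc2c1-c1cccc(Cl)c1`: 0.22 mL/min
Compound 2 `O=S(=O)(c1ccc(F)c(F)c1)c1cnc2cc(F)ccc2c1-c1cccc(Cl)c1`: 0.38 mL/min
Compound 3 `COc1ccc(-c2c(S(=O)(=O)c3ccc(F)c(F)c3)cnc3cc(F)ccc23)cc1`: 1.1 mL/min

All three share one core and differ only in two attached rings. Compound 3 has the highest number of the three. It differs from compound 2 by 4-methoxyphenyl in place of 3-chlorophenyl on an aromatic carbon, and this change gives a 2.9-fold higher number from compound 2 to compound 3 (0.46 log units; beyond the scatter). Compound 1 differs from compound 2 by 3,5-difluorophenyl in place of 3,4-difluorophenyl on a sulfonyl sulfur, and that change gives a 1.7-fold lower number from compound 2 to compound 1 (0.24 log units; within the scatter), so the two values cannot be told apart with confidence.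

Compound 4 `COc1ccc(-c2c(S(=O)(=O)c3cc(F)cc(F)c3)cnc3cc(F)ccc23)cc1` is not yet measured. It differs from compound 3 by 3,5-difluorophenyl in place of 3,4-difluorophenyl on a sulfonyl sulfur, the same change that separates compound 2 from compound 1, and at a place described in the same words. For compound 4 the expected step is therefore a 1.6-fold lower number from compound 3 to compound 4 (0.20 log units; within the scatter), resting on compound 2 and compound 1, where the step was a 1.7-fold lower number from compound 2 to compound 1 (0.24 log units; within the scatter). In this assay compound 4 is estimated at 0.7 mL/min, with a likely range from 0.35 mL/min to 1.4 mL/min.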

Compound 4, intrinsic clearance in a liver preparation (reported as CLH), per the amount of preparation that the assay uses: 1.51 mL/min
Estimate against measurement, compound 4: 2.2-fold (0.33 log units) below; measured number outside the range, above it.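

In this assay, 3,5-difluorophenyl in place of 3,4-difluorophenyl on the sulfonyl sulfur gives a 1.4-fold higher number from compound 3 to compound 4 (0.14 log units; within the scatter), so compound 3 and compound 4 cannot be told apart, and this swap leaves no measurable mark on either core: the same change on two cores in this assay, a 1.7-fold lower number (0.24 log units; within the scatter) from compound 2 to compound 1 and a 1.4-fold higher number (0.14 log units; within the scatter) from compound 3 to compound 4, 2.4-fold (0.37 log units) apart, within the scatter of two such steps. The other swap, 4-methoxyphenyl in place of 3-chlorophenyl on an aromatic carbon, gives a 6.9-fold higher number from compound 1 to compound 4 (0.84 log units; beyond the scatter), a higher number on both cores, so here the direction carries over and the two sizes agree within the scatter: the same change on two cores in this assay, a 2.9-fold higher number (0.46 log units; beyond the scatter) from compound 2 to compound 3 and a 6.9-fold higher number (0.84 log units; beyond the scatter) from compound 1 to compound 4, 2.4-fold (0.37 log units) apart, within the scatter of two such steps. This does not show that the two steps are equal in size, and two pairs of compounds cannot show that either swap would behave the same way on a further core.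

The compounds shown leave open what happens when the ring on that aromatic carbon carries something other than chlorine or methoxy, such as a nitrile or an amine. They also leave open whether these steps hold when the sulfonyl sulfur bears a ring with no fluorine at all.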